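Shortening the Ether Chain of Compound 1 to a Carboxymethyl

This account rests on a few compounds, and the source may have more. Where it says the series, first, only, none or still open, it means among the compounds named here.

Measured compounds:
compound 1 `CCOC(=O)CCCCCOc1ccc2c(=O)c(-c3ccc(O)cc3)coc2c1`, 280 nM
compound 2 `O=c1c(-c2ccc(O)cc2)coc2cc(OCCCCCCCCCCCCO)ccc12`, 1700 nM

In an assay (Cricetulus griseus) for inhibition of aldehyde dehydrogenase, mitochondrial (Homo sapiens) (a higher number here means a weaker inhibitor, a lower number a stronger inhibitor), compound 1 gives the lowest of the two numbers; its nearest neighbour is compound 2, and the step of a 6.1-fold higher number from compound 1 to compound 2 (0.78 log units; beyond the scatter) places compound 2 well beyond the scatter on the weaker side. Compound 3 `O=C(O)COc1ccc2c(=O)c(-c3ccc(O)cc3)coc2c1` has not yet been measured. It differs from compound 1 as follows: carboxy in place of 4-(ethoxycarbonyl)butyl on a saturated chain carbon bound to an oxygen on an aromatic ring.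

Going by the values given here, only the step from compound 1 to compound 2 bears on this change, and only loosely: there, the 7-hydroxyheptyl in place of ethoxycarbonyl gave a modest weakening, and the chain end was altered rather than cut back. Among the compounds with values here, no measured pair shows the ether chain shortened or a free carboxy introduced. With compound 1 at 280 nM and the one known alteration of this chain moving the number upward, a weakening is the more likely outcome, but its size is uncertain. Compound 3 is therefore estimated at 1500 nM in this assay, within a wide range of 300 nM to 8000 nM, which is expected to mean a step of a 5.4-fold higher number from compound 1 to compound 3 (0.73 log units; beyond the scatter).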

Compound 3, half-maximal inhibitory concentration: 1200 nM
Compound 3: middle estimate off by 1.3-fold (0.10 log units), on the high side, within the range that was stated.
By their numbers in this assay, from the lowest: compound 1; then compounds 3 and 2 (each within the scatter of the next).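

In this assay, putting carboxy in place of 4-(ethoxycarbonyl)butyl on the saturated chain carbon bound to an oxygen on an aromatic ring gave a 4.3-fold higher number from compound 1 to compound 3 (0.63 log units; beyond the scatter). The earlier step, a 6.1-fold higher number from compound 1 to compound 2 (0.78 log units; beyond the scatter), had shown a higher number only for a longer chain ending in a hydroxyl group, whereas this one shows the same direction for a much shorter chain ending in carboxy, so compound 1 keeps the lowest number of the three and neither change at this position improves on its ester chain. Nothing measured here bears on why either change raises the number.

Compound 3 differs from compound 1 in both chain length and chain end, so the compounds shown do not separate the contribution of shortening the chain from that of replacing the ethyl ester with a carboxylic acid. Going by these compounds, an ethyl ester on the short chain of compound 3, a carboxylic acid at the end of the longer chain of compound 1, or an amine at either chain end would each address a question that remains open.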